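The source may report more compounds than this note shows. Statements on the series, on what has been measured and on what is new or still open speak of the compounds shown alone.

Working notes on the series. Compound 1 `O=C(N/N=C/c1c(-c2cc3ccccc3oc2=O)[nH]c2ccccc12)c1ccccc1F`, compound 2 `O=C(N/N=C/c1c(-c2cc3ccccc3oc2=O)[nH]c2ccccc12)c1ccc(Cl)cc1F` and compound 3 `O=C(N/N=C/c1c(-c2cc3ccc(Br)cc3oc2=O)[nH]c2ccccc12)c1ccccc1` have been measured in a functional assay on MCF7 cells (Homo sapiens) for inhibition, read by MTT assay, with a stated time of 48 h; on this read-out lower numbers stand for stronger inhibition and higher numbers for weaker inhibition; compound 4 `O=C(N/N=C/c1c(-c2cc3ccc(Br)cc3oc2=O)[nH]c2ccccc12)c1ccc(Cl)cc1` has not. In this assay compound 1 gives > 200000 nM, which is a limit of the assay and not a number. In this assay compound 2 likewise gives > 200000 nM, again a limit and not a number. In this assay, among the compounds with values here, compound 3 gives 9100 nM, the only number in the set. The difference between the core of compound 1 and the core of compound 3 is not broken down here.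

From compound 1 to compound 2 the change is chloro in place of hydrogen on an aromatic carbon. The step is a step that the two limits leave unreadable from compound 1 to compound 2, and the limit of > 200000 nM in this assay, at which 2 of the 3 values shown sit, is the reason its size cannot be read. From compound 3 to compound 4 the change is chloro in place of hydrogen on an aromatic carbon. It is the same kind of change, but the surroundings differ: in compound 2 the entering chloro sits meta to a fluoro group and para to a large group, whereas in compound 4 it sits para to a large group only.

No readable size comes from the pair compound 1 and compound 2, so the expectation for compound 4 rests on compound 3 alone at 9100 nM. In this assay the step expected is a 1.3-fold lower number from compound 3 to compound 4 (0.11 log units; within the scatter), kept within the usual scatter, since nothing measured points either way. Compound 4 is therefore estimated at 7000 nM, with a range from 2500 nM to 25000 nM.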

Compound 4, half-maximal inhibitory concentration: 13800 nM
Estimate against measurement, compound 4: 2.0-fold (0.29 log units) below, within the range that was stated.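

In this assay, chloro in place of hydrogen on the core of compound 3, that is phenyl to 4-chlorophenyl, gives a 1.5-fold higher number from compound 3 to compound 4 (0.18 log units; within the scatter), so on this core the change leaves the two compounds inseparable on this read-out. On the core of compound 1 the same kind of change cannot be read, and the two cores cannot be compared for it, because both values on that core are limits of the assay and not numbers: the limit of > 200000 nM in this assay, at which 2 of the 4 values shown sit. The result therefore holds for compound 3 and compound 4 alone; it does not show that chloro in place of hydrogen behaves alike or differently on the core of compound 1, where a fluoro group is also present on the same ring.

The compounds shown hold no pair that differs in the core alone, so how much of the gap between the limits on the core of compound 1 and the numbers on the core of compound 3 belongs to the core stays open. Also open, from the compounds shown here alone, is whether an amine or a carboxylic acid in the place taken by chloro in compound 4 would give a step beyond the scatter.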